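This account rests on a few compounds, and the source may have more. Where it says the series, first, only, none or still open, it means among the compounds named here.

Going by the values given here, compound 1, `CC1(C)S[C@@H]2/C(=C\C(=O)c3ccc([N+](=O)[O-])cc3)C(=O)N2[C@H]1C(=O)OC(c1ccccc1)c1ccccc1`, is the weaker of the two compounds measured so far in a functional assay on A-375 cells (Homo sapiens) for cytotoxicity, read by MTT assay, with a stated time of 48 h; a lower number here means a stronger inhibitor, a higher number a weaker inhibitor. Compound 1 gives 50300 nM, the highest of the two numbers. Compound 2, `CC1(C)S[C@@H]2/C(=C\C(=O)OC(c3ccccc3)c3ccccc3)C(=O)N2[C@H]1C(=O)OC(c1ccccc1)c1ccccc1`, gives 9100 nM in this assay, and the gap between the two values lies beyond the scatter. Among the compounds with values here, no step between measured compounds covers a change at the aryl ketone alone, so the two values show only that the shared core can reach a lower number with a different group on the carbonyl carbon.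

Compound 3, `CC1(C)S[C@@H]2/C(=C\C(=O)c3cc(F)cc(F)c3)C(=O)N2[C@H]1C(=O)OC(c1ccccc1)c1ccccc1`, differs from compound 1 in one place: 3,5-difluorophenyl in place of 4-nitrophenyl on a carbonyl carbon. Within the data shown here, with no measured step of this kind available, the expected step from compound 1 to compound 3 is estimated as a 1.7-fold lower number from compound 1 to compound 3 (0.22 log units; within the scatter), a modest move toward a lower number that may well fall within the scatter. Compound 3 is therefore expected to give about 30000 nM in this assay, within a range from 8000 nM to 100000 nM.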

Compound 3, half-maximal inhibitory concentration: 19100 nM
Beside the measured number, compound 3's estimate is 1.6-fold (0.20 log units) above it; the measured number falls inside the stated range.
By their numbers in this assay, from the lowest: compound 2; then compound 3; then compound 1.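

Going by these compounds alone, with the shared core held fixed, 3,5-difluorophenyl in place of 4-nitrophenyl on a carbonyl carbon gives a 2.6-fold lower number from compound 1 to compound 3 (0.42 log units; beyond the scatter) in this assay, the first reading of a change to this aryl group alone. This shows that the number responds to the aryl group on this carbonyl carbon, which the earlier pair could not show, though the step is modest in size. Within the data shown here, nothing measured here explains the step, and the single change cannot separate the loss of the nitro group from the gain of the two fluorines.

From the compounds shown here alone, whether an unsubstituted phenyl or a phenyl carrying a single fluorine would give a similar number remains open. So does the effect of a phenyl bearing an amine or a carboxylic acid, or of a simple alkyl chain, on this carbonyl carbon.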